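Phenyl in Place of Ethynyl: What to Expect

The source may report more compounds than this note shows. Statements on the series, on what has been measured and on what is new or still open speak of the compounds shown alone.

Compound 1 `CCCCCOC(=O)Nc1nc(=O)n(C2O[C@H](C(=O)O)[C@@H](O)[C@H]2O)cc1F` and compound 2 `C=CCOC(=O)Nc1nc(=O)n(C2O[C@H](C(=O)O)[C@@H](O)[C@H]2O)cc1F` and compound 3 `C#CCOC(=O)Nc1nc(=O)n(C2O[C@H](C(=O)O)[C@@H](O)[C@H]2O)cc1F` share one core and differ only in the group on a saturated chain carbon bound to an oxygen next to a carbonyl group. In a functional assay on HCT-15 cells (Homo sapiens) for inhibition (on this read-out lower numbers stand for stronger inhibition and higher numbers for weaker inhibition), compound 1 gives 0.12 ug/mL while compound 2 gives 0.032 ug/mL and compound 3 gives 0.04 ug/mL as its reading. Compound 3 thus holds the middle of the three numbers, but a 1.3-fold higher number from compound 2 to compound 3 (0.10 log units; within the scatter) is too small to separate that pair, whereas a 3.0-fold lower number from compound 1 to compound 3 (0.48 log units; beyond the scatter) is a real though modest gap.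

Compound 4 `O=C(Nc1nc(=O)n(C2O[C@H](C(=O)O)[C@@H](O)[C@H]2O)cc1F)OCc1ccccc1` carries a further change at the same carbon: phenyl in place of ethynyl on a saturated chain carbon bound to an oxygen next to a carbonyl group with phenyl in place of ethynyl, so propargyl becomes benzyl. Within the data shown here, two measured steps bear on it. Vinyl in place of butyl gave a 3.8-fold lower number from compound 1 to compound 2 (0.57 log units; beyond the scatter) and ethynyl in place of butyl gave a 3.0-fold lower number from compound 1 to compound 3 (0.48 log units; beyond the scatter) at this carbon. Neither involves a ring, so they guide only loosely, and the direction is the less certain part. Their modest size argues against a large jump. The expected change is a 2.0-fold higher number from compound 3 to compound 4 (0.30 log units; within the scatter) as a small move toward weaker inhibition. For compound 4 the estimated value is 0.08 ug/mL within a range of 0.025 ug/mL to 0.25 ug/mL in this assay once measured.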

Compound 4, half-maximal inhibitory concentration: 0.17 ug/mL
Compound 4: middle estimate off by 2.1-fold (0.33 log units), on the low side, and the stated range covers the measured number.
By their numbers in this assay, from the lowest: compounds 2 and 3 (each within the scatter of the next); then compounds 1 and 4 (each within the scatter of the next).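

Phenyl in place of ethynyl on this saturated chain carbon gives a 4.3-fold higher number from compound 3 to compound 4 (0.63 log units; beyond the scatter) in this assay, and phenyl in place of vinyl gives a 5.3-fold higher number from compound 2 to compound 4 (0.73 log units; beyond the scatter), so this first ring at the position clearly separates compound 4 from the two compounds with small unsaturated groups. Phenyl in place of butyl gives a 1.4-fold higher number from compound 1 to compound 4 (0.15 log units; within the scatter), a step too small to separate the two, so in this short series the ring and the butyl chain read alike, while vinyl and ethynyl form the other group with the lower numbers. The data shown offer no measured reason for this split.

The compounds shown cannot tell whether the aromatic ring itself matters or whether any larger group on this carbon would read the same way, and a cyclohexyl group would test that directly. As far as these compounds go, it also remains open how a shorter saturated group such as methyl or ethyl would compare with vinyl and ethynyl, and so whether their lower numbers depend on the multiple bond at all.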